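The compounds below may be only part of what the source reports. "The series", "measured", "known", "first", "only" and "open" are said of these compounds alone.

Of the compounds shown here, three built on one shared core have been measured in a functional assay on Hs-578T cells (Homo sapiens) for inhibition, read by sulforhodamine B assay, with a stated time of 48 h; a lower number here means a stronger inhibitor of growth, a higher number a weaker inhibitor of growth. Compound 1 `O=C(Nc1cccc(-n2cc(-c3ccncc3)c(-c3ccc(Cl)c(O)c3)n2)c1)Nc1ccc(Cl)c(Cl)c1` gives 3150 nM. Compound 2 `O=C(Nc1cccc(-n2cc(-c3ccncc3)c(-c3ccc(Cl)c(O)c3)n2)c1)Nc1cc(C(F)(F)F)cc(C(F)(F)F)c1` gives 4080 nM, and compound 3 `COc1cc(-c2nn(-c3cccc(NC(=O)Nc4cccc(C(F)(F)F)c4)c3)cc2-c2ccncc2)ccc1Cl` gives 12500 nM. Compound 1 carries the lowest of the three numbers, but its gap to compound 2 lies within the usual scatter, so the two cannot be told apart, while its gap to compound 3 lies beyond the scatter.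

Compound 4 `O=C(Nc1cccc(-n2cc(-c3ccncc3)c(-c3ccc(Cl)c(O)c3)n2)c1)Nc1ccc(Cl)c(C(F)(F)F)c1` is the next compound to be tested. It differs from compound 1 in one place: trifluoromethyl in place of chloro on an aromatic carbon. Among the measured compounds shown here, no measured pair shows this single change on its own, so there is no direct step to lean on. For the measured compounds named here, the only hint comes from compound 2, whose value of 4080 nM sits within the scatter of compound 1 despite carrying trifluoromethyl groups.

On that basis compound 4 is expected to land close to compound 1, with an estimated step from compound 1 to compound 4 of a 1.1-fold higher number from compound 1 to compound 4 (0.06 log units; within the scatter), inside the scatter. The expected value for compound 4 in this assay is 3600 nM, with a likely range from 1600 nM to 8000 nM.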

Compound 4, concentration for total growth inhibition: 11200 nM
Compound 4: the middle estimate sits 3.1-fold (0.49 log units) below what was measured; measured number above the stated range.
By their numbers in this assay, from the lowest: compounds 1 and 2 (each within the scatter of the next); then compounds 4 and 3 (each within the scatter of the next).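

In this assay, among the compounds shown here, the change of chloro to trifluoromethyl, on the aromatic carbon ortho to a chloro group and meta to a large group, gives a 3.6-fold higher number from compound 1 to compound 4 (0.55 log units; beyond the scatter) as the first single-change step in this set. This position on the 3,4-dichlorophenyl group is therefore not indifferent to what it carries: with one group swapped and the rest of the molecule untouched, growth inhibition becomes weaker by a margin beyond the scatter. Nothing at hand gives the reason for this loss.

The compounds shown leave open how the same position would respond to other groups, such as methyl, bromo or nitrile, or to a plain hydrogen. They also leave open whether this swap would have a similar effect at the other chloro of the 3,4-dichlorophenyl group.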